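The source may hold more compounds than are shown below. What is called first, only, known or untested is meant among the compounds shown, and "the series" means these compounds.

In a functional assay on MCF7 cells (Homo sapiens) for antiproliferative activity, read by MTT assay, with a stated time of 48 h (a higher number here means a weaker inhibitor, a lower number a stronger inhibitor), compound 1 (`COc1ccc(-c2nc(C)c(C(=O)CSc3nc(N)c(C#N)c(-c4ccc(Cl)cc4)n3)s2)cc1`) gives 11300 nM and compound 2 (`COc1ccc(-c2nc(C)c(C(=O)CSc3nc(N)c(C#N)c(-c4ccc(OC)cc4)n3)s2)cc1`) gives 24300 nM (the higher of the two numbers). Compound 3 (`COc1ccc(-c2nc(SCC(=O)c3sc(-c4ccc(Cl)cc4)nc3C)nc(N)c2C#N)cc1`) carries chloro in place of methoxy on an aromatic carbon, turning one 4-methoxyphenyl of compound 2 into 4-chlorophenyl (chloro in place of methoxy on an aromatic carbon). Going by the values given here, the only measured step that bears on this is a 2.2-fold higher number from compound 1 to compound 2 (0.33 log units; beyond the scatter), the reverse swap at the other 4-methoxyphenyl group. The place differs. The expected step is a 1.7-fold lower number from compound 2 to compound 3 (0.24 log units; within the scatter). For compound 3 the estimate is 14000 nM (range 6000 nM to 30000 nM).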

Compound 3, half-maximal inhibitory concentration: 10100 nM
For compound 3 the middle estimate is 1.4-fold (0.14 log units) above the measured one; the range from low to high includes it.
By their numbers in this assay, from the lowest: compounds 3 and 1 (each within the scatter of the next); then compound 2.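

In this assay, chloro in place of methoxy at this second 4-methoxyphenyl group gives a 2.4-fold lower number from compound 2 to compound 3 (0.38 log units; beyond the scatter), a modest change beyond the scatter. The earlier step, a 2.2-fold higher number from compound 1 to compound 2 (0.33 log units; beyond the scatter), showed the same preference at the other 4-methoxyphenyl group, so in both places on compound 2 the chloro version has the lower number. Nothing measured here explains this preference. Going by these compounds, whether the two chloro swaps would add up in one compound remains open. So does the effect of an amine or a carboxylic acid at this position.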